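Unsaturation on the Chain Bound to the Aromatic Nitrogen

The compounds below may be only part of what the source reports. "The series", "measured", "known", "first", "only" and "open" are said of these compounds alone.

Of the compounds shown here, three with a shared core have been tested in a functional assay on MCF7 cells (Homo sapiens) for antiproliferative activity; on this read-out higher numbers stand for weaker inhibition and lower numbers for stronger inhibition. Compound 1 `CCCn1c(Cc2cc(OC)c(OC)c(OC)c2)nc2c(N)ncnc21` gives 46800 nM in this assay. Compound 2 `COc1cc(Cc2nc3c(N)ncnc3n2CC(OC)OC)cc(OC)c1OC` gives 72400 nM. Compound 3 `CCC(C)Cn1c(Cc2cc(OC)c(OC)c(OC)c2)nc2c(N)ncnc21` gives 61700 nM. Compound 3 is not separated from either neighbour: a 1.3-fold higher number from compound 1 to compound 3 (0.12 log units; within the scatter) and a 1.2-fold lower number from compound 2 to compound 3 (0.07 log units; within the scatter), so on the numbers shown all three compounds lie together. The remaining step, a 1.5-fold higher number from compound 1 to compound 2 (0.19 log units; within the scatter), is likewise within the scatter.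

Compound 4 `C/C=C/Cn1c(Cc2cc(OC)c(OC)c(OC)c2)nc2c(N)ncnc21` differs from compound 3 in one place: prop-1-en-1-yl in place of sec-butyl on a saturated chain carbon bound to an aromatic nitrogen. Every step measured so far varies the group on a saturated chain carbon bound to an aromatic nitrogen, and so all three bear on this change. None of them moved the number beyond the scatter, whether a dimethoxymethyl, an added ethyl or a sec-butyl was introduced there. Swapping a sec-butyl for a prop-1-en-1-yl is a change of the same kind, and no step of a different kind is available. Compound 4 is therefore expected to give about 55000 nM in this assay, with a range from 25000 nM to 120000 nM. The step so expected is a 1.1-fold lower number from compound 3 to compound 4 (0.05 log units; within the scatter), that is, no shift beyond the scatter.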

Compound 4, half-maximal inhibitory concentration: 51300 nM
Beside the measured number, compound 4's estimate is 1.1-fold (0.03 log units) above it; the range from low to high includes it.
By their numbers in this assay, from the lowest: compounds 1, 4, 3 and 2 (each within the scatter of the next).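

In this assay, for the compounds shown here, a double bond outside aromatic rings now appears on the chain for the first time, yet exchanging 2-methylbutyl for but-2-en-1-yl stays within the scatter (a 1.2-fold lower number from compound 3 to compound 4 (0.08 log units; within the scatter)). The comparisons with the other two compounds read the same way (a 1.4-fold lower number from compound 2 to compound 4 (0.15 log units; within the scatter); a 1.1-fold higher number from compound 1 to compound 4 (0.04 log units; within the scatter)), so all four compounds lie together, and the tolerance seen so far for saturated chains and the dimethoxymethyl-bearing chain at this place extends to one unsaturated chain, which leaves the read-out no better separated than before. Nothing available accounts for this lack of separation, so the result remains a description of the numbers and offers no explanation.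

The compounds shown leave open whether any group on a saturated chain carbon bound to an aromatic nitrogen can move the number beyond the scatter, since a primary amine, a carboxylic acid, a phenyl ring or a much longer chain does not appear there. They also leave open whether the same double bond would stay within the scatter on a shared core changed in another place.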